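The source may hold more compounds than are shown below. What is called first, only, known or untested is meant among the compounds shown, and "the series" means these compounds.

Compound 3 `CC(C)c1cccc(OC(=O)c2cn(-c3ccccc3)nc2-c2ccncc2)c1` was tested in a functional assay on HeLa cells (Homo sapiens) for cytotoxicity, read by MTT assay, with a stated time of 48 h (on this read-out lower numbers stand for stronger inhibition and higher numbers for weaker inhibition), where it gives only a limit of the assay, > 100000 nM, and not a number. Compound 1 `CC(C)c1cccc(OC(=O)c2cn(-c3ccccc3)nc2-c2cccnc2)c1` likewise reaches only a limit in this assay, > 100000 nM. Compound 2 `COc1ccc(OC(=O)c2cn(-c3ccccc3)nc2-c2ccncc2)cc1` also stays at a limit in this assay, giving > 100000 nM. Because all three values sit at the limit of > 100000 nM in this assay, at which 3 of the 3 values shown sit, the step that the two limits leave unreadable from compound 1 to compound 3 and the step that the two limits leave unreadable from compound 2 to compound 3 cannot be read in size; both start and end at the limit.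

Compound 4 `O=C(Oc1ccc2ccccc2c1)c1cn(-c2ccccc2)nc1-c1ccncc1` has not yet been measured. It differs from compound 3 in one place: naphthalen-2-yl in place of 3-isopropylphenyl on an oxygen next to a carbonyl group. Among the compounds with values here, the step from compound 2 to compound 3 also exchanged the group on this oxygen, but its size stayed unreadable, so no measured step gives a readable size for such an exchange. No shift beyond the scatter can be predicted, and the expected step is therefore a step that the limit leaves unreadable from compound 3 to compound 4. Compound 4 is estimated at 150000 nM, expected to fall between 30000 nM and 1000000 nM, most likely again at the limit of the assay.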

Compound 4, half-maximal inhibitory concentration: > 100000 nM
Compound 4 ended at the assay's limit (the forecaster's own chance of this, stated with the estimate: 85%); the middle value lies beyond the limit too.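

Compound 4 also stops at a limit, so the steps to it from compound 2 and compound 3 cannot be read in size: the limit of > 100000 nM in this assay, at which 4 of the 4 values shown sit.

The compounds shown leave open whether any of them has a measurable value in this assay and how they rank against one another.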